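Swapping a triazole for a hydroxamic-type chain at the sulfur

A few compounds are considered here, and "the series" means these few. Any claim that something is new, unique, unknown or untested is made for them only; others in the source may bear on it.

Of the compounds shown here, three sharing one core have been measured in an assay on CHO cells for displacement of a labelled ligand from adenosine receptor A1 (Homo sapiens), read by scintillation counting, with a stated time of 90 min; on this read-out higher numbers stand for weaker inhibition and lower numbers for stronger inhibition. Compound 1 `N#Cc1c(N)nc(SCc2ncn[nH]2)c(C#N)c1-c1ccc(OCC2CC2)cc1` gives 338 nM and stands highest of the three numbers. Compound 2 `C=CCOc1ccc(-c2c(C#N)c(N)nc(SCC(N)=O)c2C#N)cc1` gives 323 nM, a value that sits within the scatter of compound 1. Compound 3 `C=CCOc1ccc(-c2c(C#N)c(N)nc(SCc3ccn[nH]3)c2C#N)cc1` gives 44 nM, the lowest of the three. Among the measured compounds shown here, the single measured step is a 7.3-fold lower number from compound 2 to compound 3 (0.87 log units; beyond the scatter): replacing a small chain-borne carbamoyl with an aromatic five-membered ring on the saturated chain carbon bound to a sulfur lowered the number well beyond the scatter.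

Compound 4 `N#Cc1c(N)nc(SCC(=O)NO)c(C#N)c1-c1ccc(OCC2CC2)cc1` has not yet been measured in this assay. It differs from compound 1 as follows: hydroxycarbamoyl in place of 1H-1,2,4-triazol-5-yl on a saturated chain carbon bound to a sulfur. This change runs in the opposite sense to the measured step: an aromatic five-membered ring leaves and a small chain group with a carbonyl enters. For the measured compounds named here, on that basis, the step from compound 2 to compound 3 is the only guide, and it suggests the number should rise by a modest amount. Compound 4 is therefore expected to give 1100 nM, within a range from 300 nM to 4000 nM, an estimated step of a 3.3-fold higher number from compound 1 to compound 4 (0.51 log units; beyond the scatter) toward weaker inhibition.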

Compound 4, inhibition constant: 536 nM
Compound 4: the middle estimate sits 2.1-fold (0.31 log units) above what was measured, and the stated range covers the measured number.
By their numbers in this assay, from the lowest: compound 3; then compounds 2, 1 and 4 (each within the scatter of the next).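

In this assay, putting hydroxycarbamoyl in place of 1H-1,2,4-triazol-5-yl on a saturated chain carbon bound to a sulfur gives a 1.6-fold higher number from compound 1 to compound 4 (0.20 log units; within the scatter) and so leaves the two compounds indistinguishable: on the core of compound 1, this place does not need a ring to keep its number. The earlier exchange of carbamoyl for 1H-pyrazol-5-yl, on a different shared core, gave a 7.3-fold lower number from compound 2 to compound 3 (0.87 log units; beyond the scatter), so trading a small carbonyl chain against a five-membered aromatic ring has no single outcome here, and compound 1 and compound 4 go against any rule that a ring at this place always means a lower number. No supporting measurement bears on why the two exchanges differ.

From the compounds shown here alone, compound 3, at 44 nM, differs from compound 1 in two places, so it remains open whether its lower number belongs to the 1H-pyrazol-5-yl ring or to the other ether group. Also open, going by these compounds, is whether a carboxylic acid or a longer chain ending in an amine at this place would stay within the scatter of compound 1 or move the number beyond it.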